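The compounds below may be only part of what the source reports. "The series", "measured", "known", "first", "only" and "open" are said of these compounds alone.

In a functional assay on BJAB cells (Homo sapiens) for antiproliferative activity, with a stated time of 4 days; on this read-out higher numbers stand for an effect only at larger amounts of compound and lower numbers for an effect already at smaller amounts:
compound 1 `COc1cncc(-c2c(C)nn(-c3nc(-c4ccc(Cl)c(Cl)c4)c(SC(C)C)s3)c2C(=O)O)c1` — 21000 nM
compound 2 `Cc1nn(-c2nc(-c3ccc(Cl)c(Cl)c3)c(SC(C)C)s2)c(C(=O)O)c1-c1cnccn1` — 14000 nM
compound 3 `Cc1nn(-c2nc(-c3ccc(Cl)c(Cl)c3)c(SC(C)C)s2)c(C(=O)O)c1-c1cccc(Cl)c1` — 13600 nM

Compound 3 carries the lowest of the three numbers, but its steps to the others stay within the scatter: a 1.0-fold lower number from compound 2 to compound 3 (0.01 log units; within the scatter) and a 1.5-fold lower number from compound 1 to compound 3 (0.19 log units; within the scatter); likewise a 1.5-fold lower number from compound 1 to compound 2 (0.18 log units; within the scatter). Compound 4 `Cc1cccc(-c2c(C)nn(-c3nc(-c4ccc(Cl)c(Cl)c4)c(SC(C)C)s3)c2C(=O)O)c1` has not been measured in this assay. It differs from compound 3 by methyl in place of chloro on an aromatic carbon. Among the compounds with values here, no measured step bears directly on this exchange; the three known steps each replace the whole aryl group, and none leaves the scatter, so the read-out appears insensitive to what occupies that part of the molecule. A smaller change within that same aryl group is therefore expected to give no step beyond the scatter, a 1.0-fold higher number from compound 3 to compound 4 (0.01 log units; within the scatter). For compound 4 in this assay the estimate is 14000 nM, with a range of 6000 nM to 30000 nM.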

Compound 4, half-maximal effective concentration: 17000 nM
For compound 4 the middle estimate is 1.2-fold (0.08 log units) below the measured one, and the stated range covers the measured number.
By their numbers in this assay, from the lowest: compounds 3, 2, 4 and 1 (each within the scatter of the next).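

In this assay methyl in place of chloro on the 3-substituted phenyl ring gives a step within the scatter (a 1.3-fold higher number from compound 3 to compound 4 (0.10 log units; within the scatter)), so a single-atom exchange at this position is as silent as the whole-aryl exchanges. The 3-methylphenyl group also stays within the scatter of pyrazin-2-yl (a 1.2-fold higher number from compound 2 to compound 4 (0.08 log units; within the scatter)) and of 5-methoxypyridin-3-yl (a 1.2-fold lower number from compound 1 to compound 4 (0.09 log units; within the scatter)). No supporting data bear on this result. Still open, going by these compounds, is whether an amine or a hydroxyl on this ring would give a step beyond the scatter. Also open, on these data alone, is whether an amide in place of the carboxylic acid would do so.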